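The source may hold more compounds than are shown below. What is called first, only, known or untested is meant among the compounds shown, and "the series" means these compounds.

Measured so far in a functional assay on NCI-H292 cells (Homo sapiens) for cytotoxicity, read by MTT assay, with a stated time of 72 h, tested at 5 ug/mL; on this read-out lower numbers stand for less inhibition of growth and higher numbers for more inhibition of growth at the one concentration tested:
compound 1 `O=C1NC(=S)/C(=C/c2ccc(Cl)cc2)S1`, 35.8%
compound 2 `O=C1NC(=S)/C(=C/c2ccccc2Cl)S1`, 34.2%
compound 3 `O=C1NC(=S)/C(=C/c2ccccc2F)S1`, 25.2%

Compound 2 gives 34.2% in this assay. Its number sits close to that of compound 1, and the gap to compound 3 is also within the usual scatter, so the three measured compounds cannot be told apart on these numbers. Among the measured compounds shown here, the one measured step, a number 9 percentage points lower from compound 2 to compound 3 (within the scatter), swaps one halogen for another and stays within the scatter.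

Compound 4 `O=C1NC(=S)/C(=C/c2ccc(Cl)cc2Cl)S1` is not yet measured. It arises from compound 2 by a change in one place: chloro in place of hydrogen on an aromatic carbon. For the measured compounds named here, no measured step adds a group to a ring that already carries one, so the measured data do not cover this change directly. Going by the values given here, the only step available, from compound 2 to compound 3, shows that changing a halogen on this ring leaves the number within the scatter. On that basis compound 4 is expected to stay near compound 2, with a step of a number 2.8 percentage points higher from compound 2 to compound 4 (within the scatter) in this assay. The estimate for compound 4 is 37%, in a range from 20% to 55%.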

Compound 4, percent growth inhibition at one concentration: 29.3%
For compound 4 the middle estimate is 7.7 percentage points above the measured one, within the range that was stated.
By their numbers in this assay, from the lowest: compounds 3, 4, 2 and 1 (each within the scatter of the next, the first and the last beyond it).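

In this assay, among the compounds shown here, a second halogen on the ring can now be judged for the first time: adding chloro meta to a chloro group and para to a group of 8 heavy atoms gives a number 4.9 percentage points lower from compound 2 to compound 4 (within the scatter) and adding chloro to the other monochloro compound gives a number 6.5 percentage points lower from compound 1 to compound 4 (within the scatter) as the second reading of this change. From either starting compound, then, a second chloro on this ring leaves the number within the usual scatter. Nothing available here explains this result.

As far as these compounds go, whether a group other than a halogen on this ring, such as a methoxy group, an amine or a carboxylic acid, would move the number beyond the scatter remains open. From the compounds shown here alone, all four compounds share the same core, so the effect of a change there is also open.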